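Thiophen-3-yl Replaces 4-Ethylphenyl on a Hydroxamate Series

The source may report more compounds than this note shows. Statements on the series, on what has been measured and on what is new or still open speak of the compounds shown alone.

Compound 3 `CCc1ccc(-c2nc(CNc3ccc(C(=O)NO)cc3)n(-c3ccccc3)n2)cc1` is examined in an assay on Sf9 cells for inhibition of protein deacetylase HDAC6 (Homo sapiens), read by fluorescence, with a stated time of 40 min, tested at 100 nM (a lower number here means less inhibition, a higher number more inhibition at the concentration tested (going by the name of the read-out)), where compound 3 gives 54.6%. That is the lowest of the three numbers measured: in this assay compound 1 `O=C(NO)c1ccc(NCc2nc(-c3ccco3)nn2-c2ccccc2)cc1` gives 59.9% and compound 2 `O=C(NO)c1ccc(NCc2nc(-c3cc4ccccc4s3)nn2-c2ccccc2)cc1` gives 65.5%. Compound 4 `O=C(NO)c1ccc(NCc2nc(-c3ccsc3)nn2-c2ccccc2)cc1` carries the change (thiophen-3-yl in place of 4-ethylphenyl on an aromatic carbon). Among the compounds with values here, two measured steps bear on it, since each exchanged furan-2-yl or 1-benzothiophen-2-yl for 4-ethylphenyl: the modest fall a number 10.9 percentage points lower from compound 2 to compound 3 (beyond the scatter), beyond the scatter, and the smaller fall a number 5.3 percentage points lower from compound 1 to compound 3 (within the scatter), within it. Undoing such an exchange, a rise of about a number 5.4 percentage points higher from compound 3 to compound 4 (within the scatter) is expected for compound 4 in this assay, though it may stay within the scatter. Compound 4 is therefore estimated at 60%, with a range from 48% to 72%.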

Compound 4, a percentage reported as inhibition, at one concentration (the size of the read-out at that concentration, not a potency): 53.4%
Compound 4: middle estimate off by 6.6 percentage points, on the high side, and the stated range covers the measured number.
By their numbers in this assay, from the lowest: compounds 4, 3, 1 and 2 (each within the scatter of the next, the first and the last beyond it).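

In this assay, replacing 4-ethylphenyl with thiophen-3-yl gives no rise: the step is a number 1.2 percentage points lower from compound 3 to compound 4 (within the scatter), and the step from the furan-2-yl group is a number 6.5 percentage points lower from compound 1 to compound 4 (within the scatter). Among the steps to compound 4, only the one from the 1-benzothiophen-2-yl group is clear, at a number 12.1 percentage points lower from compound 2 to compound 4 (beyond the scatter), so a smaller aromatic ring or a different one at this position need not change the number. Nothing measured here accounts for these steps. Every group shown at this position is aromatic, so it remains open whether an amine, a carboxylic acid or a longer alkyl chain there would move the number beyond the scatter.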